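The source may hold more compounds than are shown below. What is called first, only, known or untested is meant among the compounds shown, and "the series" means these compounds.

Measured compounds in a functional assay on SW480 cells (Homo sapiens) for cytotoxicity, read by MTT assay, with a stated time of 4 days; on this read-out higher numbers stand for weaker inhibition and lower numbers for stronger inhibition:
- Compound 1 `C=C1C[C@]23C[C@@]1(O)CC[C@H]2c1ccc(OS(=O)(=O)c2ccc(C)cc2)c(C)c1[C@@H]3Cn1cc(-c2ccc(OC)cc2)nn1`; in this assay compound 1 gives > 20000 nM, which is a limit of the assay and not a number.
- Compound 2 `C=C1C[C@]23C[C@@]1(O)CC[C@H]2c1ccc(O)c(C)c1[C@@H]3Cn1cc(-c2ccc(Br)cc2)nn1`; in this assay compound 2 gives > 20000 nM, again a limit rather than a number.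
- Compound 3 `C=C1C[C@]23C[C@@]1(O)CC[C@H]2c1ccc(O)c(C)c1[C@@H]3Cn1cc(-c2ccccc2)nn1`; in this assay compound 3 gives > 20000 nM, once more a limit and not a number.

Compound 3 therefore stands at the limit of this assay, exactly where the other two measured compounds also sit, since (the limit of > 20000 nM in this assay, at which 3 of the 3 values shown sit). Among the compounds with values here, the one measured step between two compounds differing in a single place, a step that the two limits leave unreadable from compound 2 to compound 3, cannot be read because both of its ends are limits, so no measured step gives a usable size or direction.

Compound 4 `C=C1C[C@]23C[C@@]1(O)CC[C@H]2c1ccc(O)c(C)c1[C@@H]3Cn1cc(-c2ccc(OC)cc2)nn1` differs from compound 3 by methoxy in place of hydrogen on an aromatic carbon. Compound 1 also bears this methoxy group, with its phenol capped as a tosylate, and it too sits at the limit. Within the data shown here, nothing among the measured compounds points to a readable change for this step. Compound 4 is therefore expected to stay at the limit as well, with an estimated value of 30000 nM and a range from 12000 nM to 100000 nM. The expected step that the limit leaves unreadable from compound 3 to compound 4 is thus estimated to be nothing beyond the scatter.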

Compound 4, half-maximal inhibitory concentration: > 20000 nM
Compound 4 was reported as a limit; the forecaster's own chance of this, stated with the estimate: 85%; the middle value does not contradict the limit.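

No new step can be read between compound 4 and compound 1, compound 2 or compound 3, because all four sit at the same limit: the limit of > 20000 nM in this assay, at which 4 of the 4 values shown sit.

The compounds shown leave open whether swapping hydrogen, bromo, methoxy or (4-methylphenyl)sulfonyl changes cytotoxicity at all.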